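This account rests on a few compounds, and the source may have more. Where it says the series, first, only, none or still open, it means among the compounds named here.

Working notes on the series. In an assay on isolated protein for inhibition of Gonadotropin-releasing hormone receptor (Rattus norvegicus) (a lower number here means a stronger inhibitor, a higher number a weaker inhibitor), compound 3 `COc1ccc([N+](=O)[O-])cc1CSc1nc2cc(NC(=O)C3CCC3)ccc2n1C(C)C` gives 630 nM, the lowest of the two numbers so far shown. Compound 2 `COc1ccc([N+](=O)[O-])cc1CSc1nc2cc(NC(=O)OC(C)(C)C)ccc2n1C(C)C` gives 710 nM in this assay, and the step of a 1.1-fold lower number from compound 2 to compound 3 (0.05 log units; within the scatter) stays within the scatter. Compound 1 `CC(C)n1c(SCc2ccccc2Cl)nc2cc(NC(=O)C3CC3)ccc21` returns only a limit of this assay, > 10000 nM, not a number. Among the compounds with values here, compound 1 differs from compound 3 in more than one place, so no single step links the two, and the limit of > 10000 nM in this assay, at which 1 of the 3 values shown sits, tells only that the pair sit far apart.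

Compound 4 `COc1ccc([N+](=O)[O-])cc1CSc1nc2cc(NC(=O)C(C)(C)C)ccc2n1C(C)C` is the next point: tert-butyl in place of cyclobutyl on a carbonyl carbon. Within the data shown here, the one measured step at this carbonyl carbon, a 1.1-fold lower number from compound 2 to compound 3 (0.05 log units; within the scatter), was within the scatter, and the entering tert-butyl carries the same count of heavy atoms as the cyclobutyl it replaces. The step from compound 3 to compound 4 is therefore expected to stay within the scatter, a 1.0-fold higher number from compound 3 to compound 4 (0.01 log units; within the scatter). Compound 4 is estimated at 650 nM, with a range from 250 nM to 1700 nM.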

Compound 4, half-maximal inhibitory concentration: > 10000 nM
Compound 4 ended at the assay's limit; the forecaster's own chance of this, stated with the estimate: 5%; at least 15-fold (1.18 log units) between middle value and limit.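

At this carbonyl carbon, the flat step a 1.1-fold lower number from compound 2 to compound 3 (0.05 log units; within the scatter) did not mean that the group could vary freely: tert-butyl in place of cyclobutyl, with the heavy-atom count unchanged, gives an at least 15-fold higher number from compound 3 to compound 4 (1.20 log units; beyond the scatter). The absence of a ring does not account for this on its own, since tert-butoxy also has no ring and compound 2 gives 710 nM, while tert-butyl in place of tert-butoxy gives an at least 14-fold higher number from compound 2 to compound 4 (1.14 log units; beyond the scatter). Compound 4 returns only a limit, not a number, so both steps have no upper size: the limit of > 10000 nM in this assay, at which 2 of the 4 values shown sit.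

Still open, on these data alone, is whether isopropyl, cyclopentyl or a methylamino group on this carbonyl carbon would keep a measured value. Also open, as far as these compounds go, is whether the tert-butyl step would be as large with a different group in place of the isopropyl on the core.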